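Carbamate to thiocarbamate at the piperidine nitrogen

A few compounds are considered here, and "the series" means these few. Any claim that something is new, unique, unknown or untested is made for them only; others in the source may bear on it.

Compound 2 `CC(C)(C)COC(=O)N1CCC(Oc2ncnc3c2CCN3c2ccc(S(C)(=O)=O)cc2F)CC1` has the lowest of the two numbers shown, giving 39.8 nM in a functional assay on CHO-K1 cells for agonist activity at Glucose-dependent insulinotropic receptor (Homo sapiens), read by a luciferase reporter, with a stated time of 5 h; a lower number here means that less compound is needed, a higher number that more compound is needed for the effect; compound 1 `COC(=O)N1CCC(Oc2ncnc3c2CCN3c2ccc(S(C)(=O)=O)cc2F)CC1` gives 316 nM. Compound 3 `CCSC(=O)N1CCC(Oc2ncnc3c2CCN3c2ccc(S(C)(=O)=O)cc2F)CC1` carries ethylsulfanyl in place of neopentyloxy on a carbonyl carbon. Going by the values given here, the only step that bears on this change is a 7.9-fold lower number from compound 1 to compound 2 (0.90 log units; beyond the scatter), where a larger group at this end lowered the number; compound 3 moves back toward a smaller group, so a higher number is expected for compound 3, a 3.0-fold higher number from compound 2 to compound 3 (0.48 log units; beyond the scatter). Compound 3 is therefore estimated at 120 nM, within 40 nM to 400 nM.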

Compound 3, half-maximal effective concentration: 31.6 nM
For compound 3 the middle estimate is 3.8-fold (0.58 log units) above the measured one, outside the stated range (below it).
By their numbers in this assay, from the lowest: compounds 3 and 2 (each within the scatter of the next); then compound 1.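

In this assay, ethylsulfanyl in place of neopentyloxy on the carbonyl carbon gives a 1.3-fold lower number from compound 2 to compound 3 (0.10 log units; within the scatter), so this position accepts a group of 3 heavy atoms as well as one of 6. Ethylsulfanyl in place of methoxy gives a 10-fold lower number from compound 1 to compound 3 (1.00 log units; beyond the scatter), which shows that the neopentyloxy group is not needed to go beyond compound 1. Nothing available explains this result. Whether the sulfur or the ethyl chain accounts for the step from compound 1 stays open, and an ethoxy group or a longer chain on the sulfur would bear on that.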